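The source may report more compounds than this note shows. Statements on the series, on what has been measured and on what is new or still open speak of the compounds shown alone.

In a functional assay on AS49-RAW cells (Homo sapiens) for antiproliferative activity, read by sulforhodamine B assay, with a stated time of 48 h (on this read-out higher numbers stand for weaker inhibition and lower numbers for stronger inhibition), the three measured compounds gave the following numbers:

- compound 1 `N=C(N)NS(=O)(=O)c1ccc(N/C(S)=N\c2ccnc3cc(C(F)(F)F)ccc23)cc1`: 23900 nM
- compound 2 `Cc1cc(NS(=O)(=O)c2ccc(N/C(S)=N\c3ccnc4cc(C(F)(F)F)ccc34)cc2)on1`: 60200 nM
- compound 3 `O=S(=O)(Nc1ncccn1)c1ccc(N/C(S)=N\c2ccnc3cc(C(F)(F)F)ccc23)cc1`: 37800 nM

All three share the same core and differ only in the group attached to the sulfonamide nitrogen. Compound 3 gives the second highest of the three numbers, but the steps of a 1.6-fold higher number from compound 1 to compound 3 (0.20 log units; within the scatter) and a 1.6-fold lower number from compound 2 to compound 3 (0.20 log units; within the scatter) both lie within the usual scatter, so no order among these compounds can be read from them. For the measured compounds named here, the only step beyond the scatter is a 2.5-fold higher number from compound 1 to compound 2 (0.40 log units; beyond the scatter), a modest one.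

Compound 4 `Cc1cc(C)nc(NS(=O)(=O)c2ccc(N/C(S)=N\c3ccnc4cc(C(F)(F)F)ccc34)cc2)n1` differs from compound 3 by 4,6-dimethylpyrimidin-2-yl in place of pyrimidin-2-yl on a sulfonamide nitrogen. Going by the values given here, none of the measured steps tests this kind of change: each of them swaps the whole group on the sulfonamide nitrogen rather than adding methyl groups to a ring that is already present. The nearest comparison is the step from one six-membered to one five-membered ring, which stayed within the scatter. Among the compounds with values here, with no direct precedent, the expectation for compound 4 is a step of about a 1.1-fold higher number from compound 3 to compound 4 (0.02 log units; within the scatter) in this assay, that is, no change beyond the scatter. Compound 4 is therefore estimated at 40000 nM, with a range from 15000 nM to 100000 nM.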

Compound 4, half-maximal inhibitory concentration: 43400 nM
Beside the measured number, compound 4's estimate is 1.1-fold (0.04 log units) below it; the measured number falls inside the stated range.
By their numbers in this assay, from the lowest: compounds 1, 3, 4 and 2 (each within the scatter of the next, the first and the last beyond it).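

In this assay, putting 4,6-dimethylpyrimidin-2-yl in place of pyrimidin-2-yl on a sulfonamide nitrogen gives a 1.1-fold higher number from compound 3 to compound 4 (0.06 log units; within the scatter), the first direct test of adding methyl groups to a ring already present at this position, and the number stays within the scatter. The other new comparisons, a 1.4-fold lower number from compound 2 to compound 4 (0.14 log units; within the scatter) and a 1.8-fold higher number from compound 1 to compound 4 (0.26 log units; within the scatter), also lie within the scatter, so compound 4 cannot be placed in any order against compound 1, compound 2 or compound 3. No accompanying measurement accounts for this result.

Still open, as far as these compounds go, is how this position responds to groups of a different kind on the sulfonamide nitrogen, such as an acetyl group, a simple ethyl chain or a chain ending in a carboxylic acid. A phenyl ring in place of the pyrimidin-2-yl is equally untested by these compounds.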